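Aryl Ester Exchange on a Triterpenoid Scaffold

The compounds below may be only part of what the source reports. "The series", "measured", "known", "first", "only" and "open" are said of these compounds alone.

Measured compounds:
compound 1, `CC1=CCC2C(CC[C@@]2(C)O)C(C)(C)C1CC[C@@H]1[C@@]2(C)CCC(=O)C(C)(C)O[C@@H]2CC[C@]1(C)O`: > 50000 nM
compound 2, `CC1=CC[C@H]2[C@H](CC[C@]2(C)O)C(C)(C)[C@@H]1CC[C@H]1[C@]2(C)CC[C@H](OC(=O)c3ccncc3)C(C)(C)O[C@H]2CC[C@@]1(C)O`: 25300 nM

For the measured compounds named here, in a functional assay on MCF7 cells (Homo sapiens) for antiproliferative activity, read by MTT assay, with a stated time of 72 h (a lower number here means a stronger inhibitor, a higher number a weaker inhibitor), compound 2 gives 25300 nM, the only number among the two values shown. Compound 1 reaches only a limit of the assay, (the limit of > 50000 nM in this assay, at which 1 of the 2 values shown sits). Compound 3, `COc1ccc(C(=O)O[C@H]2CC[C@]3(C)[C@H](CC[C@@](C)(O)[C@H]3CC[C@@H]3C(C)=CC[C@H]4[C@H](CC[C@]4(C)O)C3(C)C)OC2(C)C)cc1`, has not yet been measured in this assay. It differs from compound 2 in one place: 4-methoxyphenyl in place of pyridin-4-yl on a carbonyl carbon. The carbonyl carbon and the oxygen attached to it remain; only the aromatic ring on that carbonyl carbon is exchanged. Going by the values given here, no step between measured compounds that differ in one place is available, so the size of this change has no counterpart among the known values. The account expects a step from compound 2 to compound 3 of a 1.2-fold lower number from compound 2 to compound 3 (0.06 log units; within the scatter), not larger than the usual scatter in either direction. Compound 3 is therefore estimated at 22000 nM, within 8000 nM to 60000 nM.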

Compound 3, half-maximal inhibitory concentration: 41700 nM
Compound 3: the middle estimate sits 1.9-fold (0.28 log units) below what was measured, within the range that was stated.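

In this assay, 4-methoxyphenyl in place of pyridin-4-yl on a carbonyl carbon gives a 1.6-fold higher number from compound 2 to compound 3 (0.22 log units; within the scatter). For the compounds shown here, this is the first step that can be read at this position, and it shows that the two aromatic rings cannot be told apart here, although one holds a ring nitrogen and the other is carbon only and carries a methoxy group. The carbonyl carbon and its oxygen stay the same in both compounds, so the exchange of the ring alone gives no change beyond the scatter.

As far as these compounds go, it remains open whether another group on this carbonyl carbon, such as a phenyl ring bearing an amine or a carboxylic acid, or a longer alkyl chain, would give a step beyond the scatter. Compound 1 stands only as a limit of the assay, and no step joins it to the other compounds: the limit of > 50000 nM in this assay, at which 1 of the 3 values shown sits.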